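The source may hold more compounds than are shown below. What is called first, only, known or untested is meant among the compounds shown, and "the series" means these compounds.

Working notes on the series. Compound 2 `COc1ccc(-c2ccc(C(=O)N[C@H](C)CCCc3cccnc3)cc2[N+](=O)[O-])cc1OC` gives 0.19 mg/kg in a functional assay on the whole organism (lung) for inhibition, with Cavia porcellus as the target; on this read-out higher numbers stand for an effect only at larger amounts of compound and lower numbers for an effect already at smaller amounts. Compound 1 `COc1ccc(-c2ccc(C(=O)N[C@H](C)CCCc3cccnc3)cc2Br)cc1OC` differs from it by bromo in place of nitro on an aromatic carbon and gives 0.4 mg/kg in this assay, the step being a 2.1-fold higher number from compound 2 to compound 1 (0.32 log units; beyond the scatter). Compound 3 `COc1ccc(-c2ccc(C(=O)NCCCCc3cccnc3)cc2[N+](=O)[O-])cc1OC` gives 0.76 mg/kg in this assay, with a 4.0-fold higher number from compound 2 to compound 3 (0.60 log units; beyond the scatter); compound 1 and compound 3 lie within the scatter of each other.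

Compound 4 `COc1ccc(-c2ccc(C(=O)NCCCCc3cccnc3)cc2Br)cc1OC` is not yet measured. Against compound 3 it shows (bromo in place of nitro on an aromatic carbon), the same change as from compound 2 to compound 1; the two cores differ by hydrogen in place of methyl on a saturated chain carbon bound to an amide-type nitrogen and a saturated chain carbon, and the surroundings of the place are described identically for both pairs. The step from compound 3 to compound 4 in this assay is expected to be a 2.1-fold higher number from compound 3 to compound 4 (0.32 log units; beyond the scatter), resting on the earlier step of a 2.1-fold higher number from compound 2 to compound 1 (0.32 log units; beyond the scatter). Compound 4 is therefore estimated at 1.6 mg/kg, expected between 0.8 mg/kg and 3.5 mg/kg.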

Compound 4, dose for 50% inhibition: 0.4 mg/kg
The estimate for compound 4 lay 4.0-fold (0.60 log units) above the measured number, outside the stated range (below it).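

In this assay bromo in place of nitro gives a 1.9-fold lower number from compound 3 to compound 4 (0.28 log units; within the scatter) on the core without the chain methyl, so the step seen on the core carrying that methyl does not carry over: the same change on two cores in this assay, a 2.1-fold higher number (0.32 log units; beyond the scatter) from compound 2 to compound 1 and a 1.9-fold lower number (0.28 log units; within the scatter) from compound 3 to compound 4, 4.0-fold (0.60 log units) apart, beyond the scatter of two such steps. Hydrogen in place of methyl gives no change at the digits printed from compound 1 to compound 4 (within the scatter) with bromo on the aromatic carbon, and this too differs from the step seen with nitro there: the same change on two cores in this assay, a 4.0-fold higher number (0.60 log units; beyond the scatter) from compound 2 to compound 3 and no change at the digits printed (within the scatter) from compound 1 to compound 4, 4.0-fold (0.60 log units) apart, beyond the scatter of two such steps. The two changes are thus not independent across these four compounds, but the data do not show why, and one such set gives no rule for other cores.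

The compounds shown leave open how chloro or an amine in place of nitro would behave on either core. Also open, going by these compounds, is whether ethyl in place of the chain methyl would follow either pattern.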